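The source may report more compounds than this note shows. Statements on the series, on what has been measured and on what is new or still open speak of the compounds shown alone.

Compound 1 `Fc1cccc(-c2nc(Nc3ccccc3)c3cc(F)ccc3n2)c1`: 47800 nM
Compound 2 `Fc1cccc(-c2nc(Nc3cccc(Cl)c3)c3cc(F)ccc3n2)c1`: > 50000 nM, a limit
Compound 3 `Fc1cccc(-c2nc(Nc3cccc(Br)c3)c3cc(F)ccc3n2)c1`: > 50000 nM, a limit

In a functional assay on MDA-MB-231 cells (Homo sapiens) for cytotoxicity, read by MTT assay, with a stated time of 48 h (on this read-out higher numbers stand for weaker inhibition and lower numbers for stronger inhibition), compound 3 stands at > 50000 nM, which is a limit and not a number. That puts it at the limit of > 50000 nM in this assay, at which 2 of the 3 values shown sit. Compound 4 `Nc1ccc(Nc2nc(-c3cccc(F)c3)nc3ccc(F)cc23)cc1` carries 4-aminophenyl in place of 3-bromophenyl on a nitrogen on an aromatic ring. The nearest measured steps are an at least 1.0-fold higher number from compound 1 to compound 2 (0.01 log units; that floor lies within the scatter) and an at least 1.0-fold higher number from compound 1 to compound 3 (0.01 log units; that floor lies within the scatter), and both concern halogens rather than an amino group. Going by the values given here, the only number as a guide is compound 1 at 47800 nM. A modest move toward stronger inhibition is therefore expected, an at least 1.6-fold lower number from compound 3 to compound 4 (0.22 log units; that floor lies within the scatter). Compound 4 is estimated at 30000 nM, with an expected range from 8000 nM to 60000 nM.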

Compound 4, half-maximal inhibitory concentration: > 50000 nM
Compound 4: only a limit was reported; the forecaster's own chance of this, stated with the estimate: 35%; middle value at least 1.6-fold (0.22 log units) away from the limit.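

In this assay compound 4 gives > 50000 nM, which is a limit and not a number. For the added amino group, the step reads an at least 1.0-fold higher number from compound 1 to compound 4 (0.01 log units; that floor lies within the scatter), so an amino group, like the chloro and bromo groups before it, gives no sign of stronger inhibition. The steps from compound 2 and from compound 3 to compound 4 cannot be read, and the values gather at one point: the limit of > 50000 nM in this assay, at which 3 of the 4 values shown sit. The compounds shown leave open whether a carboxylic acid or a longer chain on the ring carried by this nitrogen would give a readable number. They also leave open how far the values of compound 2, compound 3 and compound 4 lie past their shared limit.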